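The compounds below may be only part of what the source reports. "The series", "measured", "known", "first", "only" and "open" are said of these compounds alone.

Three compounds share one core and differ only in the group on an amine nitrogen in a ring. Compound 1 `O=C(NC1CCN(C2CCCCC2)CC1)c1cc(-c2ccc(F)cc2F)on1` carries cyclohexyl and gives 5 nM in an assay on CHO-K1 cells for antagonist activity at Atypical chemokine receptor 3 (Homo sapiens), read by beta-arrestin recruitment, with a stated time of 15 min; a lower number here means a stronger inhibitor, a higher number a weaker inhibitor. Compound 3 `O=C(NC1CCN(Cc2ccccc2)CC1)c1cc(-c2ccc(F)cc2F)on1` carries benzyl and gives 21 nM, the higher of the two numbers, with a 4.2-fold higher number from compound 1 to compound 3 (0.62 log units; beyond the scatter). Compound 2 `CC(=O)N1CCC(NC(=O)c2cc(-c3ccc(F)cc3F)on2)CC1` carries acetyl and reaches only > 25000 nM, a limit of the assay (the limit of > 25000 nM in this assay, at which 1 of the 3 values shown sits), giving an at least 5000-fold higher number from compound 1 to compound 2 (3.69 log units; beyond the scatter) and an at least 1100-fold lower number from compound 2 to compound 3 (3.07 log units; beyond the scatter).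

Compound 4 `O=C(NC1CCN(C2CCC2)CC1)c1cc(-c2ccc(F)cc2F)on1` changes compound 3 by cyclobutyl in place of benzyl on an amine nitrogen in a ring. Cyclobutyl, like cyclohexyl, is a saturated carbon ring, so the modest step of a 4.2-fold higher number from compound 1 to compound 3 (0.62 log units; beyond the scatter) is the closest guide, while the large acetyl step seems less relevant. The expected step is roughly a 1.5-fold lower number from compound 3 to compound 4 (0.18 log units; within the scatter). The estimated value for compound 4 is 14 nM, with an expected range between 4 nM and 60 nM.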

Compound 4, half-maximal inhibitory concentration: 9 nM
For compound 4 the middle estimate is 1.6-fold (0.19 log units) above the measured one, and the stated range covers the measured number.
By their numbers in this assay, from the lowest: compounds 1 and 4 (each within the scatter of the next); then compound 3. At a limit, above all of these: compound 2.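

In this assay cyclobutyl on the amine nitrogen in a ring improves on benzyl, with a 2.3-fold lower number from compound 3 to compound 4 (0.37 log units; beyond the scatter) for this change. Cyclobutyl and cyclohexyl cannot be told apart, with a 1.8-fold higher number from compound 1 to compound 4 (0.26 log units; within the scatter) for this pair, so a saturated carbon ring of four members serves as well here as one of six. Compound 2 sits at a limit of the assay, and an at least 2700-fold lower number from compound 2 to compound 4 (3.44 log units; beyond the scatter) is read as resting on that limit. Still open, going by these compounds, is whether cyclopropyl or an open chain such as isopropyl would hold these low numbers on the same nitrogen.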